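Adding a bromo to compound 3

The source may report more compounds than this note shows. Statements on the series, on what has been measured and on what is new or still open speak of the compounds shown alone.

Measured so far in an ADME assay on J774 cells (Mus musculus) for cytotoxicity; a lower number here means that less compound is needed, a higher number that more compound is needed for the effect:
- compound 1 `COC(=O)c1c[nH]c2cc(F)ccc2c1=O`: > 20000 nM
- compound 2 `O=c1cc[nH]c2cc(OCCOc3ccccc3)ccc12`: > 20000 nM
- compound 3 `CCCCc1cc2c(=O)cc[nH]c2cc1OCCOc1ccccc1`: > 20000 nM

Compound 3 stands only at a limit, > 20000 nM in this assay, and not at a number. The other two compounds offer no number either, as the series shows (the limit of > 20000 nM in this assay, at which 3 of the 3 values shown sit). Compound 4 `CCCCc1cc2c(=O)c(Br)c[nH]c2cc1OCCOc1ccccc1` differs from compound 3 by a single change, bromo in place of hydrogen on an aromatic carbon. Going by the values given here, the one measured step that bears on this is a step that the two limits leave unreadable from compound 2 to compound 3, which placed butyl in place of hydrogen on an aromatic carbon. Among the compounds with values here, no measured step involves a bromo, so no size or direction can be carried over from the series. All that can be expected is that compound 4 stays close to where compound 3 sits, with the most likely result another limit. The expected step is a number no higher from compound 3 to compound 4 (the limit leaves the size open), with none expected beyond the scatter. For compound 4 the estimated value is 20000 nM, with an expected range from 7000 nM to 40000 nM.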

Compound 4, half-maximal effective concentration: 8070 nM
For compound 4 the middle estimate is 2.5-fold (0.39 log units) above the measured one, within the range that was stated.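

In this assay, bromo in place of hydrogen on an aromatic carbon, two atoms from the ring nitrogen, gives an at least 2.4-fold lower number from compound 3 to compound 4 (0.39 log units; beyond the scatter), so this position can carry a change that registers beyond the scatter. Compound 4 is the only compound shown that reads as a number and not as a limit of the assay: the limit of > 20000 nM in this assay, at which 3 of the 4 values shown sit. The earlier step that placed butyl cannot be read, with both of its ends at a limit, so this is the first readable effect of any change in the series.

Going by these compounds, the true size of the step stays open, with compound 3 at a limit, and so does whether the step depends on the butyl that compound 4 carries. On these data alone, whether chloro, iodo or an amine on the same carbon would shift the number in the same direction also remains open.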